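Extending the hydroxycarbamoyl chain of compound 2

This account rests on a few compounds, and the source may have more. Where it says the series, first, only, none or still open, it means among the compounds named here.

Going by the values given here, only two compounds have numbers so far. Compound 1 (`O=C(CCCCCCC(=O)Nc1nc2ccc([N+](=O)[O-])cc2s1)NO`) gives 1.28 ug/mL in a functional assay on PC-3 cells (Homo sapiens) for cytotoxicity (on this read-out lower numbers stand for stronger inhibition and higher numbers for weaker inhibition), and compound 2 (`CCOc1ccc2nc(NC(=O)CCCCC(=O)NO)sc2c1`) gives 6.69 ug/mL there. Compound 2 therefore holds the higher of the two numbers and the weaker inhibition, and its gap to compound 1 lies beyond the scatter. Compound 3 (`CCOc1ccc2nc(NC(=O)CCCCCCC(=O)NO)sc2c1`) differs from compound 2 in one place (2-(hydroxycarbamoyl)ethyl in place of hydroxycarbamoyl on a saturated chain carbon, four bonds along the chain from a carbonyl carbon), with 2-(hydroxycarbamoyl)ethyl in place of hydroxycarbamoyl on a saturated chain carbon, four bonds along the chain from a carbonyl carbon. Among the compounds with values here, no measured pair shows this change alone, so any expectation is loose. It leans on compound 1, whose 1.28 ug/mL marks the stronger end seen so far. An estimated 2.4-fold lower number from compound 2 to compound 3 (0.38 log units; beyond the scatter) is expected, in the direction of stronger inhibition. For compound 3 the estimated value is 2.8 ug/mL within a range of 0.9 ug/mL to 8 ug/mL in this read-out.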

Compound 3, half-maximal inhibitory concentration: 16.9 ug/mL
Compound 3: middle estimate off by 6.0-fold (0.78 log units), on the low side; measured number outside the range, above it.
By their numbers in this assay, from the lowest: compound 1; then compound 2; then compound 3.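

In this assay, lengthening the chain on the ethoxy-bearing core weakens inhibition rather than strengthening it: 2-(hydroxycarbamoyl)ethyl in place of hydroxycarbamoyl gives a 2.5-fold higher number from compound 2 to compound 3 (0.40 log units; beyond the scatter), a modest step. With the longer chain held fixed, ethoxy in place of nitro on an aromatic carbon gives a 13-fold higher number from compound 1 to compound 3 (1.12 log units; beyond the scatter), a large step towards weaker inhibition, so this aromatic position now has a direct comparison of its own. Nothing available accounts for either step.

From the compounds shown here alone, it remains open whether lengthening the chain would act in the same direction with nitro on the core, and whether a still longer chain would extend the loss. Also open, going by these compounds, is how an amine or a carboxylic acid on that aromatic carbon would compare with nitro and ethoxy.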